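Trading a Carbamate Chain for a Dimethylamide Chain

A few compounds are considered here, and "the series" means these few. Any claim that something is new, unique, unknown or untested is made for them only; others in the source may bear on it.

Compound 1 `CC1=C(N2CC2)C(=O)C(C(C)C)=C(N2CC2)C1=O` and compound 2 `CC1=C(N2CC2)C(=O)C(C(C)COC(N)=O)=C(N2CC2)C1=O` share one core and differ only in a side chain. In a functional assay on L1210 cells (Mus musculus), with a stated time of 1 days (a lower number here means a less potent compound, a higher number a more potent compound, by a factor of ten per unit of this negative logarithm), compound 1 gives 4.69, and compound 2 gives 5.31. Compound 2 stands highest of the two numbers; its nearest neighbour is compound 1, and the step of a number 0.62 log units higher from compound 1 to compound 2 (beyond the scatter) came with carbamoyloxy in place of hydrogen on a saturated chain carbon, two bonds along the chain from a double-bonded ring carbon.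

Compound 3 `CC1=C(N2CC2)C(=O)C(CCC(=O)N(C)C)=C(N2CC2)C1=O` has not been measured. It differs from compound 2 by a group of 7 heavy atoms (5 carbon, 1 nitrogen, 1 oxygen; no ring) in place of a group of 7 heavy atoms (4 carbon, 1 nitrogen, 2 oxygen; no ring), on a double-bonded ring carbon. Within the data shown here, only one measured step bears on this change, and only loosely: the gain of a number 0.62 log units higher from compound 1 to compound 2 (beyond the scatter) arrived together with the carbamoyloxy group that now departs, while a group of the same size but with a different make-up enters. Because compound 1 without that group gives 4.69, part of that gain is expected to be given back, with wide uncertainty. The step expected is a number 0.31 log units lower from compound 2 to compound 3 (beyond the scatter). For compound 3 in this assay the estimate is 5, within a range from 4.5 to 5.5.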

Compound 3, logarithm of the reciprocal of the active concentration, log(1/C): 4.84
The estimate for compound 3 lay 0.16 log units above the measured number; measured number inside the range.
By their numbers in this assay, from the lowest: compounds 1 and 3 (each within the scatter of the next); then compound 2.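

In this assay the 2-(dimethylcarbamoyl)ethyl chain does not hold on to the number seen with the carbamate chain of compound 2: the exchange gives a number 0.47 log units lower from compound 2 to compound 3 (beyond the scatter) even though the incoming and outgoing groups have the same heavy-atom count, so size alone does not account for the number at this double-bonded ring carbon. Against the isopropyl group of compound 1 the same chain gives a number 0.15 log units higher from compound 1 to compound 3 (within the scatter) and so brings no gain that can be told from the scatter, which means that among these three compounds only the carbamate chain stands clear of the others, and a chain ending in a carbonyl and a nitrogen is not enough to do the same. Nothing measured here explains the difference between the two chains.

As far as these compounds go, compound 3 differs from compound 2 in several features at once, since it lacks the chain oxygen, the amide hydrogens and the methyl branch, so the feature that matters remains open. A 2-carbamoylethyl chain, which keeps the amide hydrogens, or an unbranched 2-(carbamoyloxy)ethyl chain on the same core could begin to separate these features.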